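The compounds below may be only part of what the source reports. "The series", "measured", "known", "first", "only" and "open" are said of these compounds alone.

Compound 1 `COc1ccc(Oc2ccc3c(NCCCNCc4cc(F)ccc4OC)ccnc3c2)cc1` has the highest of the three numbers in an ADME assay on HepG2 cells (Homo sapiens) for cytotoxicity, read by luminescence, CellTiter-Glo and ATP content, with a stated time of 72 h; on this read-out higher numbers stand for an effect only at larger amounts of compound and lower numbers for an effect already at smaller amounts: compound 1 gives 7000 nM. Compound 2 `COc1ccc(F)cc1CNCCCNc1ccnc2cc(CCC(C)C)ccc12` gives 890 nM and compound 3 `COc1ccc(F)cc1CNCCCNc1ccnc2cc(Oc3ccccc3)ccc12` gives 1500 nM, so the steps are a 7.9-fold lower number from compound 1 to compound 2 (0.90 log units; beyond the scatter) and a 4.7-fold lower number from compound 1 to compound 3 (0.67 log units; beyond the scatter), each a swap on an aromatic carbon of the shared core. Between the two smaller compounds, a 1.7-fold higher number from compound 2 to compound 3 (0.23 log units; within the scatter). Compound 4 `COc1ccc(Oc2ccc3c(NCCCNCc4ccco4)ccnc3c2)cc1` differs from compound 1 at the other end of the chain: furan-2-yl in place of 5-fluoro-2-methoxyphenyl on a saturated chain carbon bound to an amine nitrogen. For the measured compounds named here, none of the measured steps touches that part of the molecule, so they offer no direct guide, and the number for compound 4 is expected to stay close to that of compound 1. The expected step is a 1.3-fold higher number from compound 1 to compound 4 (0.11 log units; within the scatter). Compound 4 is therefore estimated at 9000 nM, within 3500 nM to 25000 nM.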

Compound 4, half-maximal effective concentration: 5300 nM
Estimate against measurement, compound 4: 1.7-fold (0.23 log units) above, and the stated range covers the measured number.
By their numbers in this assay, from the lowest: compounds 2 and 3 (each within the scatter of the next); then compounds 4 and 1 (each within the scatter of the next).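

Putting furan-2-yl in place of 5-fluoro-2-methoxyphenyl, on a saturated chain carbon bound to an amine nitrogen, gives a 1.3-fold lower number from compound 1 to compound 4 (0.12 log units; within the scatter) in this assay. At this end of the molecule, a five-membered aromatic ring with one hetero atom therefore reads the same as the larger fluorinated and methoxylated six-membered ring, unlike the swaps on the aromatic carbon that led to compounds 2 and 3. No measurement shown here offers an explanation for this result. As far as these compounds go, whether a cyclohexyl or pyridine ring at this place would also leave the number within the scatter stays open. So does whether furan-2-yl would behave the same alongside the isopentyl or phenoxy group.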